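The compounds below may be only part of what the source reports. "The series", "measured", "known", "first", "only" and "open" are said of these compounds alone.

Measured compounds in hand:

- Compound 1 `COC[C@H]1C[C@@](CC(C)C)(C(=O)O)N(C(=O)c2ccc(C(C)(C)C)c(OC)c2)[C@@H]1c1nccs1`; in an ADME assay on Huh-5-2 cells (Homo sapiens) for cytotoxicity, with a stated time of 3 days (a higher number here means that more compound is tolerated, a lower number that less compound is tolerated), compound 1 gives 200000 nM.
- Compound 2 `COC[C@H]1C[C@@](CC(C)C)(C(=O)O)N(C(=O)c2ccc(C(C)(C)C)c(OC)c2)[C@H]1[C@H]1COC(C)(C)O1`; in this assay compound 2 reaches only the limit > 120000 nM, a bound of the measurement and not a number.
- Compound 3 `COC[C@H]1C[C@@](CC(C)C)(C(=O)O)N(C(=O)c2ccc(C(C)(C)C)c(OC)c2)[C@H]1COC`; in this assay compound 3 likewise stops at the limit > 120000 nM, again a bound and not a number.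

Where compound 3 stands: its value in this assay is a limit only, and one further value shown is also a limit, so compound 3 cannot be placed against the others with any precision. For the measured compounds named here, the one step between measured compounds, a step that the two limits leave unreadable from compound 2 to compound 3, is unreadable, since both of its ends sit at the bound (the limit of > 120000 nM in this assay, at which 2 of the 3 values shown sit). Going by the values given here, compound 1 is the only numbered value, and it lies close to that same region.

Compound 4 `COC[C@H]1C[C@@](CC(C)C)(C(=O)O)N(C(=O)c2ccc(C(C)(C)C)c(OC)c2)[C@H]1CNC(C)=O` differs from compound 3 by acetamido in place of methoxy on a saturated chain carbon bound to a saturated ring carbon. Among the compounds with values here, no measured step bears on this change; nothing carries an acetamido group, and the one step that exists gives no size at all. What the three values do show is that this series is tolerated up to or beyond the top of the range tested. The expectation is therefore a step that the limit leaves unreadable from compound 3 to compound 4 of no readable size, and most likely another limit. Compound 4 is estimated at 150000 nM in this assay, with a range from 60000 nM to 400000 nM.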

Compound 4, half-maximal cytotoxic concentration: > 120000 nM
Compound 4: a limit, no number (the forecaster's own chance of this, stated with the estimate: 80%); the middle value is on the limit's open side.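

In this assay compound 4 gives > 120000 nM, a limit and not a number. No step from compound 3 or compound 2 to compound 4 can be read, because all three compounds stop at the same bound: the limit of > 120000 nM in this assay, at which 3 of the 4 values shown sit.

The compounds shown leave open whether acetamido in place of methoxy changes the tolerated concentration at all.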